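The compounds below may be only part of what the source reports. "The series", "measured", "known", "first", "only" and "open" are said of these compounds alone.

Three compounds that share one core and differ only in the ring attached to the carbonyl carbon have been tested in a functional assay on SR cells (Homo sapiens) for inhibition, read by sulforhodamine B assay, with a stated time of 48 h; on this read-out lower numbers stand for stronger inhibition of growth and higher numbers for weaker inhibition of growth. Compound 1 `COc1cc(-c2cc(/C=C/C(=O)c3ccc(N)cc3)[nH]n2)cc(OC)c1OC` carries a 4-aminophenyl there and gives 320 nM. Compound 2 `COc1cc(-c2cc(/C=C/C(=O)c3ccc(Cl)c(Cl)c3)[nH]n2)cc(OC)c1OC` carries a 3,4-dichlorophenyl and gives 390 nM. Compound 3 `COc1ccc(C(=O)/C=C/c2cc(-c3cc(OC)c(OC)c(OC)c3)n[nH]2)cc1OC` carries a 3,4-dimethoxyphenyl and gives 270 nM. All three numbers sit close together: the step from compound 1 to compound 2 is a 1.2-fold higher number from compound 1 to compound 2 (0.09 log units; within the scatter), from compound 1 to compound 3 it is a 1.2-fold lower number from compound 1 to compound 3 (0.07 log units; within the scatter), and from compound 2 to compound 3 it is a 1.4-fold lower number from compound 2 to compound 3 (0.16 log units; within the scatter). Compound 3 therefore has the lowest number of the three, but none of its gaps to the others reaches beyond the usual scatter.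

Compound 4 `COc1cc(-c2cc(/C=C/C(=O)c3ccc(F)c(F)c3)[nH]n2)cc(OC)c1OC` has not yet been measured. It differs from compound 3 in one place: 3,4-difluorophenyl in place of 3,4-dimethoxyphenyl on a carbonyl carbon. For the measured compounds named here, the step that bears most directly on this change is the one from compound 2 to compound 3, where a dihalogenated ring was exchanged for the dimethoxy ring and the number moved by a 1.4-fold lower number from compound 2 to compound 3 (0.16 log units; within the scatter). Since every exchange of this ring so far has stayed within the scatter, compound 4 is expected to give 350 nM, most likely between 170 nM and 720 nM, a change of a 1.3-fold higher number from compound 3 to compound 4 (0.11 log units; within the scatter) in this assay that would not be beyond the scatter.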

Compound 4, concentration for 50% growth inhibition: 2920 nM
For compound 4 the middle estimate is 8.3-fold (0.92 log units) below the measured one, and the stated range ends below it.
By their numbers in this assay, from the lowest: compounds 3, 1 and 2 (each within the scatter of the next); then compound 4.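

The earlier compounds shown here made this ring on the carbonyl carbon look forgiving, since three quite different rings gave numbers within the scatter of one another in this assay. Compound 4 shows that the position is not indifferent to what it carries: there is an 11-fold higher number from compound 3 to compound 4 (1.03 log units; beyond the scatter), and compound 4 stands just as clearly apart from the amino-bearing ring, with a 9.1-fold higher number from compound 1 to compound 4 (0.96 log units; beyond the scatter). The closest comparison is with the other dihalogenated ring, where exchanging 3,4-dichlorophenyl for 3,4-difluorophenyl still gives a 7.5-fold higher number from compound 2 to compound 4 (0.87 log units; beyond the scatter), so having two halogens on the ring does not by itself keep the activity, and the identity of the halogen matters in this pair, leaving compound 4 as the weakest of the four.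

Nothing measured here explains why compound 4 stands apart from the other three. From the compounds shown here alone, it also remains open whether the loss belongs to fluorine generally or to this particular pair of fluorines, which a 4-fluorophenyl, a 3-fluorophenyl or a plain phenyl ring on the same carbonyl carbon could help to separate.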